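Dimethylphenyl for dichlorophenyl on a spiro triazine core

The source may hold more compounds than are shown below. What is called first, only, known or untested is meant among the compounds shown, and "the series" means these compounds.

Measured compounds:
compound 1, `NC1=NC2(CCOCC2)N(OCCCOc2ccc(Cl)c(Cl)c2)C(N)=N1`, 90 nM
compound 2, `NC1=NC2(CCSCC2)N(OCCCOc2ccc(Br)cc2)C(N)=N1`, 20 nM

Of the compounds shown here, two have been measured in a functional assay on HCT-116 cells (Homo sapiens) for antiproliferative activity, read by MTT assay, with a stated time of 72 h; on this read-out lower numbers stand for stronger inhibition and higher numbers for weaker inhibition. Compound 1 gives 90 nM, the higher of the two numbers; compound 2 gives 20 nM, a lower number that lies beyond the usual scatter. For the measured compounds named here, compound 2 differs from compound 1 in more than one place, so no single step between them is defined, and the pair shows only that the two values differ.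

The step followed here leads from compound 1 to compound 3, `Cc1cc(C)cc(OCCCON2C(N)=NC(N)=NC23CCOCC3)c1`. The change is 3,5-dimethylphenyl in place of 3,4-dichlorophenyl on an oxygen on a saturated carbon. The two groups that leave and enter are of the same count and shape, and both lack donors and acceptors, so no large shift in this assay is expected. Going by the values given here, the data contain no measured step of this kind to lean on. In this assay compound 3 is expected to give a number near that of compound 1, perhaps somewhat higher, with a step of a 1.7-fold higher number from compound 1 to compound 3 (0.22 log units; within the scatter) that may stay within the scatter. The estimate for compound 3 is 150 nM, with a range from 50 nM to 500 nM.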

Compound 3, half-maximal inhibitory concentration: 190 nM
Estimate against measurement, compound 3: 1.3-fold (0.10 log units) below; low and high end bracket the measured number.
By their numbers in this assay, from the lowest: compound 2; then compound 1; then compound 3.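

In this assay, for the compounds shown here, the exchange of 3,4-dichlorophenyl for 3,5-dimethylphenyl on an oxygen on a saturated carbon gives a 2.1-fold higher number from compound 1 to compound 3 (0.32 log units; beyond the scatter) and is the only single-place step in this set. It shows that the number responds to the aromatic group at this place, even when the groups that leave and enter have the same count of heavy atoms and neither has hydrogen-bond donors or acceptors, though the step is modest and only just clears the usual scatter. The step changes both the kind of the two ring substituents and the pattern in which they stand, so it cannot separate the effect of chlorine giving way to methyl from that of the new arrangement. Nothing measured here accounts for the step.

On these data alone, whether the same exchange would produce a step of similar size on the core of compound 2 remains open. Also open, as far as these compounds go, is how a phenyl ring carrying a trifluoromethyl group, a methoxy group or a nitrile would stand at this place.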